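This account rests on a few compounds, and the source may have more. Where it says the series, first, only, none or still open, it means among the compounds named here.

Compound 1 `COc1cc(-c2cnn3cc(OC)c(-c4cc(C)no4)nc23)ccn1`: 31%
Compound 2 `Cn1cc(-c2nc3c(-c4ccnc(OC5CC5)c4)cnn3cc2OCCCC(C)(C)O)cn1`: 54%

In an ADME assay on microsomes from liver (Homo sapiens) for metabolic stability, with a stated time of 60 min, tested at 1 uM (on this read-out lower numbers stand for a less stable compound and higher numbers for a more stable compound), compound 1 gives 31%, the lower of the two numbers, while compound 2 gives 54%, a gap beyond the usual scatter. Compound 3 `COc1cc(-c2cnn3cc(OC)c(N(C)C)nc23)ccn1` keeps the core of compound 1 but has dimethylamino in place of 3-methyl-1,2-oxazol-5-yl on an aromatic carbon. Within the data shown here, no measured pair shows what a single change like this does, so no step beyond the scatter is expected in this assay. The estimated change is a number 1 percentage points lower from compound 1 to compound 3 (within the scatter). For compound 3 the expected value is 30%, with an estimated range from 12% to 55%.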

Compound 3, percent of the compound remaining: 16%
Estimate against measurement, compound 3: 14 percentage points above; low and high end bracket the measured number.
By their numbers in this assay, from the lowest: compound 3; then compound 1; then compound 2.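

Among these compounds, compound 3 gives the first comparison in this assay that changes a single place, and replacing 3-methyl-1,2-oxazol-5-yl with dimethylamino on this aromatic carbon is a number 15 percentage points lower from compound 1 to compound 3 (beyond the scatter). So what sits at this position, ortho to a methoxy group, does matter for how much compound remains. No available measurement explains why the value falls.

Going by these compounds, it remains open whether the loss follows from removing the ring or from the amine itself. A phenyl or a morpholine at this position would help separate those two readings.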